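The compounds below may be only part of what the source reports. "The series", "measured", "known", "first", "only" and "open" are said of these compounds alone.

In an ADME assay on microsomes from liver (Mus musculus) for metabolic stability, read by LC-MS, using NADPH, with a stated time of 45 min, tested at 0.5 uM (a higher number here means faster removal of the compound, a lower number slower removal), the three measured compounds stand as follows: compound 1 `O=C(CCSc1nc2cc(Cl)ccc2o1)N1CCC1` gives 17.9 mL/min/g; compound 2 `CN1CCN(C(=O)CCSc2nc3cc(Cl)ccc3o2)CC1` gives 41.5 mL/min/g; compound 3 `O=C(CCSc1nc2cc(Cl)ccc2o1)N1CCS(=O)(=O)C1` gives 8.9 mL/min/g.

Compound 2 gives the highest number of the three, with a 2.3-fold higher number from compound 1 to compound 2 (0.37 log units; beyond the scatter) and a 4.7-fold lower number from compound 2 to compound 3 (0.67 log units; beyond the scatter) both beyond the scatter, while a 2.0-fold lower number from compound 1 to compound 3 (0.30 log units; within the scatter) stays within it. Compound 4 `CS(=O)(=O)N1CCN(C(=O)CCSc2nc3cc(Cl)ccc3o2)CC1` arises from compound 2 by methylsulfonyl in place of methyl on an amine nitrogen in a ring. Among the measured compounds shown here, no measured step makes exactly this exchange; the nearest analogy is the step in which the 1,1-dioxo-1,3-thiazolidin-3-yl group enters, a 4.7-fold lower number from compound 2 to compound 3 (0.67 log units; beyond the scatter), a modest fall. Compound 4 is therefore expected to show a 2.6-fold lower number from compound 2 to compound 4 (0.41 log units; beyond the scatter), a modest fall rather than a rise, by analogy with a 4.7-fold lower number from compound 2 to compound 3 (0.67 log units; beyond the scatter). Compound 4 is estimated at 16 mL/min/g, expected to fall between 7 mL/min/g and 34 mL/min/g.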

Compound 4, intrinsic clearance in a liver preparation (reported as CLH), per the amount of preparation that the assay uses: 1.4 mL/min/g
For compound 4 the middle estimate is 11-fold (1.06 log units) above the measured one; measured number below the stated range.
By their numbers in this assay, from the lowest: compound 4; then compounds 3 and 1 (each within the scatter of the next); then compound 2.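

On the amine nitrogen of this ring, the exchange of methyl for methylsulfonyl gives in this assay the largest step in the series, a 30-fold lower number from compound 2 to compound 4 (1.47 log units; beyond the scatter) and the only one of large size. The earlier compounds shown here showed only modest steps or steps within the scatter, all made by replacing the whole group on the carbonyl carbon; this one shows that a change on the ring nitrogen alone, with the piperazine ring kept, can move the number much further. No evidence at hand accounts for the size of this step. From the compounds shown here alone, whether an acetyl group or a plain hydrogen on that nitrogen would give a similar number remains open. So does whether a longer chain on the sulfonyl, such as ethylsulfonyl, would keep it.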